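Saturated Chlorinated Chain Replacing a Dienyl Amide

The source may hold more compounds than are shown below. What is called first, only, known or untested is meant among the compounds shown, and "the series" means these compounds.

Measured compounds:
compound 1 `CCC/C=C/C(=O)N(Cc1ccc(OC)c(O)c1)c1cc(OC)c(OC)c(OC)c1`, 70 nM
compound 2 `C/C=C/C=C/C(=O)N(Cc1ccc(OC)c(O)c1)c1cc(OC)c(OC)c(OC)c1`, 140 nM
compound 3 `COc1ccc(CNc2cc(OC)c(OC)c(OC)c2)cc1Br`, 29400 nM

In a functional assay on MGC-803 cells (Homo sapiens) for inhibition, read by MTT assay, with a stated time of 48 h (on this read-out higher numbers stand for weaker inhibition and lower numbers for stronger inhibition), compound 2 gives 140 nM, the second highest of the three numbers. Its nearest neighbour is compound 1, and the step of a 2.0-fold higher number from compound 1 to compound 2 (0.30 log units; within the scatter) lies within the usual scatter of the measurement. Compound 3, which carries no carbonyl group on the nitrogen at all, gives a far higher number, 29400 nM.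

Compound 4 `COc1ccc(CN(C(=O)CCCCCl)c2cc(OC)c(OC)c(OC)c2)cc1O` is not yet measured. The change from compound 2 is 4-chlorobutyl in place of penta-1,3-dien-1-yl on a carbonyl carbon.

For the measured compounds named here, the only measured step that speaks to this change is a 2.0-fold higher number from compound 1 to compound 2 (0.30 log units; within the scatter), where one double bond was added to the chain and the number barely moved. Compound 4 removes both double bonds and adds a chlorine, a larger change than any step seen, so some shift in this assay is possible, but no direction is indicated. A step of about a 1.1-fold higher number from compound 2 to compound 4 (0.06 log units; within the scatter) is therefore expected, and compound 4 is estimated at 160 nM, in the range 50 nM to 600 nM.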

Compound 4, half-maximal inhibitory concentration: 540 nM
For compound 4 the middle estimate is 3.4-fold (0.53 log units) below the measured one, and the stated range covers the measured number.
By their numbers in this assay, from the lowest: compounds 1 and 2 (each within the scatter of the next); then compound 4; then compound 3.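

In this assay, for the compounds shown here, the carbonyl carbon turns out to be sensitive to the chain it carries: 4-chlorobutyl in place of penta-1,3-dien-1-yl gives a 3.9-fold higher number from compound 2 to compound 4 (0.59 log units; beyond the scatter) and is the first step at this position to lie beyond the scatter. Set against the pent-1-en-1-yl chain, the same 4-chlorobutyl chain gives a 7.7-fold higher number from compound 1 to compound 4 (0.89 log units; beyond the scatter) and so points the same way, with a higher number than either chain that keeps a double bond. Nothing available here explains this shift.

Compound 4 loses the double bonds and gains a chlorine in a single change, so it remains open which of the two accounts for the higher number. On these data alone, a plain pentyl chain would help separate the two, and whether an amine or a carboxylic acid at the chain end would be tolerated also remains open.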